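Trading an Aminophenyl for a Difluorophenyl

The source may report more compounds than this note shows. Statements on the series, on what has been measured and on what is new or still open speak of the compounds shown alone.

Measured so far in a functional assay on SR cells (Homo sapiens) for cytotoxicity, read by sulforhodamine B assay, with a stated time of 48 h, tested at 10 uM; on this read-out higher numbers stand for a weaker effect at the one concentration tested and lower numbers for a stronger effect:
- compound 1, `COc1cc(-c2cc(/C=C/C(=O)c3ccc(N)cc3)[nH]n2)cc(OC)c1OC`, gives -18%
- compound 2, `COc1ccc(-c2cc(/C=C/C(=O)c3ccc(OC)c(OC)c3)[nH]n2)cc1`, gives -29%
- compound 3, `COc1ccc(-c2cc(/C=C/C(=O)c3ccc(N)cc3)[nH]n2)cc1`, gives -12%

Among these three numbers, compound 1 stands second highest. Its nearest neighbour is compound 3, whose value lies within the usual scatter of compound 1, so the two cannot be told apart on this read-out. Compound 2 is the furthest away: its number lies beyond the scatter below compound 1, so compound 2 shows the stronger effect of the pair in this assay.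

Compound 4, `COc1cc(-c2cc(/C=C/C(=O)c3ccc(F)c(F)c3)[nH]n2)cc(OC)c1OC`, has not yet been measured. It differs from compound 1 in one place: 3,4-difluorophenyl in place of 4-aminophenyl on a carbonyl carbon. For the measured compounds named here, nothing among the three measured compounds involves a change of this kind, so no measured step can guide the expectation directly, and the three values all sit in a fairly narrow band.

On that basis compound 4 is expected to land close to compound 1, with a step from compound 1 to compound 4 of a number 2 percentage points lower from compound 1 to compound 4 (within the scatter), which is not expected to go beyond the scatter in either direction. The estimate for compound 4 in this assay is -20%, with a range from -45% to 5%.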

Compound 4, a percentage reported as activity, at one concentration (the size of the read-out at that concentration, not a potency): 11%
For compound 4 the middle estimate is 31 percentage points below the measured one, outside the stated range (above it).
By their numbers in this assay, from the lowest: compound 2; then compounds 1 and 3 (each within the scatter of the next); then compound 4.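

Compound 1 and compound 4 differ only in the group on a carbonyl carbon, and this pair shows that the group there matters in this assay: 3,4-difluorophenyl in place of 4-aminophenyl gives a number 29 percentage points higher from compound 1 to compound 4 (beyond the scatter), so the swap weakens the effect at the one concentration tested. The leaving 4-aminophenyl counts 1 hydrogen-bond donor and 1 hydrogen-bond acceptor and the entering 3,4-difluorophenyl counts 0 of each, a difference that travels with the step but is not shown to produce it. Nothing measured here explains why this swap moves the number as it does.

On these data alone, the swap removes the amine and brings in two fluorines at once, so it stays open which of these carries the step, and a plain phenyl or a 4-fluorophenyl on the same carbonyl carbon would help to separate the two. As far as these compounds go, it also stays open whether 3,4-difluorophenyl would give a step of similar size on the core of compound 3, which carries the same 4-aminophenyl but differs from compound 1 elsewhere.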